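The source may report more compounds than this note shows. Statements on the series, on what has been measured and on what is new or still open speak of the compounds shown alone.

Measured compounds in a functional assay on UACC-62 cells (Homo sapiens) for antiproliferative activity, read by sulforhodamine B assay, with a stated time of 48 h; on this read-out higher numbers stand for weaker inhibition and lower numbers for stronger inhibition:
compound 1, `COc1cc(-c2nn(-c3ccc(NC(=O)Nc4ccc(Cl)c(C(F)(F)F)c4)cc3)cc2-c2ccncc2)ccc1Cl`, 1770 nM
compound 2, `COc1cc(-c2nn(-c3ccc(NC(=O)Nc4cc(C(F)(F)F)cc(C(F)(F)F)c4)cc3)cc2-c2ccncc2)ccc1Cl`, 1550 nM
compound 3, `O=C(Nc1ccc(-n2cc(-c3ccncc3)c(-c3ccc(Cl)c(O)c3)n2)cc1)Nc1ccc(Cl)c(C(F)(F)F)c1`, 1700 nM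

Compound 2 gives the lowest of these three numbers, yet its gaps to compound 3 and to compound 1 both lie within the scatter, so the three stand level. Compound 4, `O=C(Nc1ccc(-n2cc(-c3ccncc3)c(-c3ccc(Cl)c(O)c3)n2)cc1)Nc1cc(C(F)(F)F)cc(C(F)(F)F)c1`, arises from compound 2 by hydrogen in place of methyl on an oxygen on an aromatic ring. Going by the values given here, the one measured step that bears on this is the same exchange on the other urea partner, a 1.0-fold lower number from compound 1 to compound 3 (0.02 log units; within the scatter), which stayed within the scatter. On that basis the step of no change at the digits printed from compound 2 to compound 4 (within the scatter) is expected to show no shift beyond the scatter. Compound 4 is therefore estimated at 1550 nM, with a range from 800 nM to 3100 nM.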

Compound 4, half-maximal inhibitory concentration: 2230 nM
For compound 4 the middle estimate is 1.4-fold (0.16 log units) below the measured one, within the range that was stated.
By their numbers in this assay, from the lowest: compounds 2, 3, 1 and 4 (each within the scatter of the next).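

In this assay, the exchange of methoxy for hydroxy now has a second reading, on the urea partner with two trifluoromethyl groups: a 1.4-fold higher number from compound 2 to compound 4 (0.16 log units; within the scatter). The exchange therefore stays within the scatter on both urea partners, and the two readings agree within the scatter as well: the same change on two cores in this assay, a 1.0-fold lower number (0.02 log units; within the scatter) from compound 1 to compound 3 and a 1.4-fold higher number (0.16 log units; within the scatter) from compound 2 to compound 4, 1.5-fold (0.18 log units) apart, within the scatter of two such steps.

The compounds shown leave open whether this position accepts a group other than methoxy or hydroxy, such as an amine or a longer alkoxy chain like ethoxy.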